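A few compounds are considered here, and "the series" means these few. Any claim that something is new, unique, unknown or untested is made for them only; others in the source may bear on it.

Compound 1 `Cc1ccccc1Oc1ccc(C#N)cc1S(=O)(=O)NC(=O)NC(C)(C)C` gives 966 nM in a functional assay on cells (Platelet, Homo sapiens) for inhibition, with a stated time of 1 min, tested at 1 uM (a higher number here means a weaker inhibitor, a lower number a stronger inhibitor), the highest of the two numbers measured; compound 2 `Cc1cccc(Oc2ccc(C#N)cc2S(=O)(=O)NC(=O)NC(C)(C)C)c1` gives 705 nM, and the step of a 1.4-fold lower number from compound 1 to compound 2 (0.14 log units; within the scatter) lies within the scatter. Compound 3 `Cc1ccc(Nc2ccc(C#N)cc2S(=O)(=O)NC(=O)NC(C)(C)C)cc1` differs from compound 1 in one place: (4-methylphenyl)amino in place of 2-methylphenoxy on an aromatic carbon. Among the measured compounds shown here, no measured step swaps an oxygen link for an amino link, and the one step that is known, a methyl moving around its ring, changed nothing beyond the scatter. Compound 3 is therefore expected to give about 900 nM, between 300 nM and 3000 nM, which means an expected step of a 1.1-fold lower number from compound 1 to compound 3 (0.03 log units; within the scatter).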

Compound 3, half-maximal inhibitory concentration: 504 nM
The estimate for compound 3 lay 1.8-fold (0.25 log units) above the measured number; measured number inside the range.
By their numbers in this assay, from the lowest: compounds 3, 2 and 1 (each within the scatter of the next).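

In this assay, a (4-methylphenyl)amino group on this aromatic carbon, para to a cyano group, reads much like either methylphenoxy group (a 1.9-fold lower number from compound 1 to compound 3 (0.28 log units; within the scatter); a 1.4-fold lower number from compound 2 to compound 3 (0.15 log units; within the scatter)). A nitrogen link carrying a hydrogen-bond donor can therefore replace the oxygen link here without a change beyond the scatter. No evidence on why is available for this result.

From the compounds shown here alone, each step changes the link and the methyl's place on the ring together, so their separate contributions stay open. Also open, going by these compounds, is how a piperidine or a benzyl group would read on this carbon.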